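The source may hold more compounds than are shown below. What is called first, only, known or untested is meant among the compounds shown, and "the series" means these compounds.

Compound 1 `Nc1nc2ccccn2c1-c1ccc(O)cc1` is a small molecule measured in an assay on isolated protein for inhibition of ubiquitin carboxyl-terminal hydrolase 1 (Homo sapiens); a higher number here means a weaker inhibitor, a lower number a stronger inhibitor. In this assay compound 1 gives > 100000 nM, which is a limit of the assay and not a number. Compound 2 `CC(C)Nc1nc2ccccn2c1-c1ccc(O)cc1` carries an isopropyl in place of hydrogen on a nitrogen on an aromatic ring. In this assay compound 2 gives > 100000 nM, again a limit. The step that the two limits leave unreadable from compound 1 to compound 2 cannot be read, since both values sit at the limit of > 100000 nM in this assay, at which 2 of the 2 values shown sit. Compound 3 `Cc1cccn2c(-c3ccc(O)cc3)c(N)nc12` differs from compound 1 in a different way: methyl in place of hydrogen on an aromatic carbon. Among the compounds with values here, no measured step touches this kind of change, and the single step that was measured, from compound 1 to compound 2, has no readable size, so nothing can be carried over. With compound 1 standing only at a limit, the best expectation is that compound 3 stays near that same region. The step that the limit leaves unreadable from compound 1 to compound 3 is therefore estimated to be none beyond the scatter. Compound 3 is expected to give about 150000 nM in this assay, within a range of 40000 nM to 600000 nM.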

Compound 3, half-maximal inhibitory concentration: > 100000 nM
Compound 3 gave a limit, no number; the forecaster's own chance of this, stated with the estimate: 85%; the middle value lies beyond the limit too.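

Compound 3, like compound 1, gives a limit of the assay and not a number, so the step for methyl in place of hydrogen on an aromatic carbon cannot be read. All three compounds stand at the same limit: the limit of > 100000 nM in this assay, at which 3 of the 3 values shown sit.

The compounds shown leave open whether any change to the shared core gives a readable number in this assay.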